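A few compounds are considered here, and "the series" means these few. Any claim that something is new, unique, unknown or untested is made for them only; others in the source may bear on it.

Compound 1 `O=C(NCc1ccccc1)c1csc(-c2c[nH]c3ccccc23)n1` in a functional assay on LNCaP C4-2 cells (Homo sapiens) for cytotoxicity, read by MTT assay, with a stated time of 48 h, in the absence of a further agent; on this read-out higher numbers stand for weaker inhibition and lower numbers for stronger inhibition: > 100000 nM, which is a limit of the assay rather than a number.
Compound 2 `O=C(Nc1ccccc1)c1csc(-c2c[nH]c3ccccc23)n1` in this assay: > 100000 nM, likewise a limit of the assay.

Going by the values given here, the one change measured so far, a step that the two limits leave unreadable from compound 1 to compound 2, cannot be read as a size, since both ends of it are limits. Compound 2 therefore has no place on a scale of numbers; it stands only at the limit of > 100000 nM in this assay, at which 2 of the 2 values shown sit, and every value shown so far sits at that same limit.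

Compound 3 `Cc1ccc(NC(=O)c2csc(-c3c[nH]c4ccccc34)n2)cc1` is the next compound, differing from compound 2 by methyl in place of hydrogen on an aromatic carbon. Among the compounds with values here, nothing measured bears on the size of such a change: the only step recorded is unreadable, and no number is known for compound 2 itself. The expectation for compound 3 therefore rests on the shared starting point alone, and compound 3 is expected most likely to sit at the limit again, with a small chance of a readable value. The estimate for compound 3 is 150000 nM, within 30000 nM to 1000000 nM, meaning an expected step that the limit leaves unreadable from compound 2 to compound 3 that is itself uncertain.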

Compound 3, half-maximal inhibitory concentration: > 100000 nM
Compound 3 was reported as a limit; the forecaster's own chance of this, stated with the estimate: 75%; the middle value does not contradict the limit.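

In this assay compound 3 gives > 100000 nM, which is a limit of the assay and not a number. The steps to compound 3 from compound 1 and from compound 2 therefore cannot be read. The compounds shown leave open what size any of these changes has, and whether a related compound would give a readable value, because all of them stand at one limit: the limit of > 100000 nM in this assay, at which 3 of the 3 values shown sit.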